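This account rests on a few compounds, and the source may have more. Where it says the series, first, only, none or still open, it means among the compounds named here.

Measured compounds:
- Compound 1, `N=C(NCCCc1c[nH]cn1)NCCCC(c1ccccc1)c1ccccn1`: 1
- Compound 2, `N=C(NCCCc1c[nH]cn1)NCCC(c1ccc(Cl)cc1)c1ccccn1`: 1

In a functional assay on cardiac atrium for agonist activity at histamine H2 receptor (Cavia porcellus) (a lower number here means a smaller maximal response, a higher number a larger maximal response), compound 1 gives 1, a full response relative to the reference agonist. Compound 2, which carries a chloro group on one of its aromatic rings, gives 1 in this assay, level with compound 1 within the scatter of repeated measurements; the two values show no difference that can be read as real.

Compound 3, `N=C(NCCCc1c[nH]cn1)NCCC(c1ccc(Cl)c(Cl)c1)c1ccccn1`, has not yet been measured. It differs from compound 2 by chloro in place of hydrogen on an aromatic carbon. Because compound 2 already reaches 1, a full response, no step beyond the scatter is expected for this change in this assay, and a decrease is no more likely than none. The expected step of no change at the digits printed from compound 2 to compound 3 (within the scatter) is accordingly close to nil. Compound 3 is therefore estimated to give 1 in this assay, with a range from 0.85 to 1.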

Compound 3, intrinsic activity: the largest response reached, as a fraction of the reference agonist's: 1
Compound 3: middle estimate and measured number agree at the digits printed; the range from low to high includes it.
By their numbers in this assay, from the lowest: compounds 1, 2 and 3 (each within the scatter of the next).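

Placing a second chloro group on the ring, ortho to the first, gives no change at the digits printed from compound 2 to compound 3 (within the scatter) in this assay, so the 3,4-dichlorophenyl compound keeps the full response seen with the 4-chlorophenyl compound. This position on the aromatic ring therefore tolerates a chlorine atom with no drop in maximal response that can be read, which compounds 1 and 2 alone could not show. Nothing at hand explains this result.

On these data alone, whether the full response would also hold with an amine, a carboxylic acid or a methoxy group at this position remains open. Also open, as far as these compounds go, is how much of each compound is needed to reach that response, which a maximal response does not tell.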